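Cytotoxicity notes: carbamate to sulfonamide on the side chain

A few compounds are considered here, and "the series" means these few. Any claim that something is new, unique, unknown or untested is made for them only; others in the source may bear on it.

Compound 1 `Cc1cc(C#N)cc(C)c1Oc1ccnc(Nc2ccc(CN3CCC(NC(=O)OC(C)(C)C)CC3)cc2)n1` and compound 2 `Cc1cc(C#N)cc(C)c1Oc1ccnc(Nc2ccc(CNC3CCN(C(=O)OC(C)(C)C)CC3)cc2)n1` share the core with a cyano group and differ only in how the side chain is built. In an ADME assay on MT4 cells (Homo sapiens) for cytotoxicity, read by MTT assay, with a stated time of 5 days (a lower number here means that less compound is tolerated, a higher number that more compound is tolerated), compound 1 gives 4340 nM and compound 2 gives 3510 nM. Compound 3 `Cc1cc(/C=C/C#N)cc(C)c1Oc1ccnc(Nc2ccc(CN3CCC(NC(=O)OC(C)(C)C)CC3)cc2)n1` carries 2-cyanoethenyl in place of cyano on the aromatic carbon; in this assay compound 3 gives 3550 nM. The step of a 1.2-fold lower number from compound 1 to compound 3 (0.09 log units; within the scatter) is within the scatter. Compound 3 stands second highest of the three numbers, nearest compound 2 and furthest compound 1, both gaps within the scatter; the three numbers sit close together.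

Compound 4 `Cc1cc(/C=C/C#N)cc(C)c1Oc1ccnc(Nc2ccc(CN3CCC(NS(C)(=O)=O)CC3)cc2)n1` awaits measurement. The change is methylsulfonyl in place of tert-butoxycarbonyl on an amine nitrogen. Among the compounds with values here, no measured pair shows this exchange; the only measured step, a 1.2-fold lower number from compound 1 to compound 3 (0.09 log units; within the scatter), concerns the aromatic substituent and gives no guidance on the side chain. With all three numbers within the scatter of one another, the expected step is none beyond the scatter, a 1.0-fold lower number from compound 3 to compound 4 (0.01 log units; within the scatter). Compound 4 is therefore estimated at 3500 nM, with a range from 1500 nM to 8000 nM.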

Compound 4, half-maximal cytotoxic concentration: 6990 nM
The estimate for compound 4 lay 2.0-fold (0.30 log units) below the measured number; measured number inside the range.
By their numbers in this assay, from the lowest: compounds 2, 3, 1 and 4 (each within the scatter of the next).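

In this assay, within the data shown here, methylsulfonyl in place of tert-butoxycarbonyl on the amine nitrogen gives a 2.0-fold higher number from compound 3 to compound 4 (0.29 log units; within the scatter), the one measured exchange on the side chain itself. With the 2-cyanoethenyl group held constant, a sulfonamide of 4 heavy atoms therefore stands in for a carbamate of 7 on this nitrogen, with no step beyond the scatter. Nothing at hand explains the size of this step.

On these data alone, it remains open whether a free amine, an acetyl group or a longer alkylsulfonyl chain on this nitrogen would also stay within the scatter of compound 3. Also open is whether methylsulfonyl would read the same with the cyano group of compound 1 on the aromatic carbon, since the side-chain exchange is shown only with 2-cyanoethenyl.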